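Oxazole carboxamide piperazines: aryl change on the ring nitrogen

A few compounds are considered here, and "the series" means these few. Any claim that something is new, unique, unknown or untested is made for them only; others in the source may bear on it.

Measured compounds:
Compound 1: `Cc1nc(-c2ccccc2F)c(C(=O)N2CCN(c3cc(Cl)cc(Cl)c3)CC2)o1`, 60.2 nM
Compound 2: `Cc1nc(-c2cccc(F)c2)c(C(=O)N2CCN(c3cc(Cl)cc(Cl)c3)CC2)o1`, 41.7 nM

Among the measured compounds shown here, in a functional assay on HL-60 cells (Homo sapiens) for inhibition, read by MTT assay, with a stated time of 72 h (on this read-out lower numbers stand for stronger inhibition and higher numbers for weaker inhibition), compound 1 gives 60.2 nM, the higher of the two numbers measured so far; compound 2 gives 41.7 nM, and the step of a 1.4-fold lower number from compound 1 to compound 2 (0.16 log units; within the scatter) separates them, so the two are not distinguished by this read-out.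

Compound 3 is `Cc1ccc(C)c(N2CCN(C(=O)c3oc(C)nc3-c3ccccc3F)CC2)c1`. It differs from compound 1 in this way: 2,5-dimethylphenyl in place of 3,5-dichlorophenyl on an amine nitrogen in a ring

For the measured compounds named here, the only measured step, from compound 1 to compound 2, changes the fluorophenyl on the oxazole and leaves the group on the piperazine nitrogen untouched; it does not bear on the change to compound 3. Going by the values given here, with no step of this kind measured, no direction beyond the scatter is expected, only a wide range of uncertainty.

Compound 3 is therefore expected to give 110 nM, between 30 nM and 450 nM, an expected step of a 1.8-fold higher number from compound 1 to compound 3 (0.26 log units; within the scatter).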

Compound 3, half-maximal inhibitory concentration: 319 nM
Compound 3: middle estimate off by 2.9-fold (0.46 log units), on the low side; the measured number falls inside the stated range.
By their numbers in this assay, from the lowest: compounds 2 and 1 (each within the scatter of the next); then compound 3.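

In this assay the group on the amine nitrogen in a ring affects the number: with 2,5-dimethylphenyl in place of 3,5-dichlorophenyl there is a 5.3-fold higher number from compound 1 to compound 3 (0.72 log units; beyond the scatter) and this contrasts with the earlier fluorophenyl step, which stayed within the scatter. The two groups match in heavy-atom count and in their one six-membered aromatic ring of carbon only, and neither has a hydrogen-bond donor, acceptor or net charge, so these counts do not separate them. No supporting data explain this step.

This single pair cannot separate the exchange of chlorine for methyl from the shift in substitution pattern; that would take 3,5-dimethylphenyl or 2,5-dichlorophenyl on this nitrogen. Also open, on these data alone, is whether 2,5-dimethylphenyl gives a similar step when paired with the 3-fluorophenyl of compound 2.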